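Triazole-linked flavanone series: nitrite inhibition in macrophages

A few compounds are considered here, and "the series" means these few. Any claim that something is new, unique, unknown or untested is made for them only; others in the source may bear on it.

Measured so far:
- Compound 1, `COc1ccc([C@@H]2CC(=O)c3c(O)cc(OCc4cn(Cc5ccc(F)cc5)nn4)cc3O2)cc1O`: 15100 nM
- Compound 2, `COc1ccc([C@@H]2CC(=O)c3c(O)cc(OCc4cn(Cc5ccc(C(F)(F)F)cc5)nn4)cc3O2)cc1O`: 17700 nM
- Compound 3, `C=CCn1cc(COc2cc(O)c3c(c2)O[C@H](c2ccc(OC)c(O)c2)CC3=O)nn1`: 13800 nM

All three share one core and differ only in the group on the saturated chain carbon bound to the aromatic nitrogen. In a functional assay on RAW264.7 cells (Mus musculus) for inhibition, read by Griess assay, with stated times of 2 h and 24 h (on this read-out lower numbers stand for stronger inhibition and higher numbers for weaker inhibition), compound 3 gives the lowest of the three numbers, but its gaps to the others are small: a 1.1-fold lower number from compound 1 to compound 3 (0.04 log units; within the scatter) and a 1.3-fold lower number from compound 2 to compound 3 (0.11 log units; within the scatter) both sit within the scatter, as does a 1.2-fold higher number from compound 1 to compound 2 (0.07 log units; within the scatter). Going by the values given here, the series so far shows no separation at all.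

Compound 4, `COc1ccc([C@@H]2CC(=O)c3c(O)cc(OCc4cn(Cc5ccccc5C)nn4)cc3O2)cc1O`, is the next step from compound 3: 2-methylphenyl in place of vinyl on a saturated chain carbon bound to an aromatic nitrogen. The two measured steps that bear on it are the reverse cases, where vinyl took the place of a substituted phenyl on the same saturated chain carbon, and both stayed within the scatter. A return to an aryl group of this kind is therefore expected to move the number little, if at all, in this assay.

Compound 4 is estimated at 15000 nM (range 8000 nM to 30000 nM), which is expected to correspond to a 1.1-fold higher number from compound 3 to compound 4 (0.04 log units; within the scatter).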

Compound 4, half-maximal inhibitory concentration: 13100 nM
The estimate for compound 4 lay 1.1-fold (0.06 log units) above the measured number; the measured number falls inside the stated range.
By their numbers in this assay, from the lowest: compounds 4, 3, 1 and 2 (each within the scatter of the next).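

In this assay the change from vinyl to 2-methylphenyl on a saturated chain carbon bound to an aromatic nitrogen gives a 1.1-fold lower number from compound 3 to compound 4 (0.02 log units; within the scatter) and so shows that a methyl-bearing aryl group, like the earlier vinyl swaps in reverse, does not separate from the rest. The comparisons with the other aryl groups read the same way, with a 1.2-fold lower number from compound 1 to compound 4 (0.06 log units; within the scatter) and with a 1.4-fold lower number from compound 2 to compound 4 (0.13 log units; within the scatter) and thus no separation among the four compounds, whether the aryl group carries methyl, fluoro or trifluoromethyl. Nothing measured here offers an explanation for this flat response.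

The compounds shown leave open whether any group on this carbon can move the number beyond the scatter, for example a carboxylic acid or an amine on a longer chain. They also leave open whether the shared core, rather than this position, governs the read-out.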